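Cytotoxicity notes: the step from compound 2 to compound 3

This account rests on a few compounds, and the source may have more. Where it says the series, first, only, none or still open, it means among the compounds named here.

In a functional assay on CCRF-CEM cells (Homo sapiens) for cytotoxicity (on this read-out lower numbers stand for higher toxicity in this test and higher numbers for lower toxicity in this test), compound 1 `CSCOC1(C)COC(C)(CC(=O)O)C1` gives > 250000 nM, which is a limit of the measurement and not a number. Among the measured compounds shown here, compound 2 `CSCO[C@@]1(C)CO[C@@](C)(CC(=O)OC[C@H]2O[C@@H](n3cc(C)c(=O)[nH]c3=O)C[C@@H]2O[Si](C)(C)C(C)(C)C)C1` gives 36000 nM, the only true number so far. Compound 3 `CSCO[C@@]1(C)CO[C@@](C)(CC(=O)OC[C@H]2O[C@@H](n3cc(C)c(=O)[nH]c3=O)C[C@@H]2O)C1` differs from compound 2 in one place: a hydrogen atom in place of a group of 7 heavy atoms (6 carbon, 1 silicon; no ring), on an oxygen on a saturated carbon, a hydrogen atom in place of a group of 7 heavy atoms, on an oxygen on a saturated carbon. For the measured compounds named here, no measured pair isolates this change, so the expectation is tentative. A moderate shift towards lower toxicity is expected in this assay, since compound 2 at 36000 nM carries the group that leaves. The estimated step is a 3.3-fold higher number from compound 2 to compound 3 (0.52 log units; beyond the scatter). For compound 3 the expected value is 120000 nM, with an estimated range of 40000 nM to 300000 nM.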

Compound 3, half-maximal cytotoxic concentration: > 250000 nM
Compound 3 gave a limit, no number; the forecaster's own chance of this, stated with the estimate: 35%; middle value at least 2.0-fold (0.31 log units) from the limit.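

In this assay, a hydrogen atom in place of the group of 7 heavy atoms (6 carbon, 1 silicon; no ring), on an oxygen on a saturated carbon, gives an at least 6.9-fold higher number from compound 2 to compound 3 (0.84 log units; beyond the scatter). Compound 3 gives > 250000 nM, which is a limit of the measurement and not a number. This is the first single change in the series, and it ties the only true number so far to the presence of this group on this oxygen, while the size of the step remains a lower bound: the limit of > 250000 nM in this assay, at which 2 of the 3 values shown sit.

The compounds shown leave open how far the value of compound 3 lies from that limit. They also leave open whether a smaller group on this oxygen, such as an acetyl or a methyl, would keep the value of compound 2 at 36000 nM.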